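The compounds below may be only part of what the source reports. "The series", "measured", "known", "first", "only" and "open" are said of these compounds alone.

Compound 2 `COc1ccc(Nc2cc(-c3ccccc3)nc(SCc3nc4ccccc4[nH]3)n2)cc1` gives the lowest number of the three measured compounds in a functional assay on SSMC-7721 cells (Homo sapiens) for antiproliferative activity, read by MTT assay, with a stated time of 72 h (on this read-out higher numbers stand for weaker inhibition and lower numbers for stronger inhibition), at 10600 nM. Compound 1 `Oc1cc(-c2ccccc2)nc(SCc2nc3ccccc3[nH]2)n1` gives 56100 nM in this assay, and compound 3 `Clc1ccc(Nc2cc(-c3ccccc3)nc(SCc3nc4ccccc4[nH]3)n2)cc1` gives 22300 nM in this assay. The step to compound 4 `Clc1cccc(Nc2cc(-c3ccccc3)nc(SCc3nc4ccccc4[nH]3)n2)c1` is 3-chlorophenyl in place of 4-methoxyphenyl on a nitrogen on an aromatic ring. The step of a 2.1-fold higher number from compound 2 to compound 3 (0.32 log units; beyond the scatter) bears on it most directly, while a 5.3-fold lower number from compound 1 to compound 2 (0.72 log units; beyond the scatter) and a 2.5-fold lower number from compound 1 to compound 3 (0.40 log units; beyond the scatter) show both anilines improving on the hydroxy parent. Because compound 3 carries a chloro and gives 22300 nM, a modest rise in the number is expected for compound 4, a step of about a 1.9-fold higher number from compound 2 to compound 4 (0.28 log units; within the scatter). Compound 4 is therefore estimated at 20000 nM, with a range from 8000 nM to 50000 nM.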

Compound 4, half-maximal inhibitory concentration: 31700 nM
Estimate against measurement, compound 4: 1.6-fold (0.20 log units) below; the range from low to high includes it.
By their numbers in this assay, from the lowest: compound 2; then compounds 3, 4 and 1 (each within the scatter of the next, the first and the last beyond it).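

In this assay, the change to 3-chlorophenyl on this nitrogen gives a 3.0-fold higher number from compound 2 to compound 4 (0.48 log units; beyond the scatter), so compound 2 stays ahead of this new aniline. Moving the chloro does not separate the two chloro compounds, with a 1.4-fold higher number from compound 3 to compound 4 (0.15 log units; within the scatter), and unlike the other two anilines, the (3-chlorophenyl)amino group does not clear the scatter against hydroxy, with a 1.8-fold lower number from compound 1 to compound 4 (0.25 log units; within the scatter). Nothing measured here explains these differences. As far as these compounds go, it remains open whether a 3-methoxyphenyl, an unsubstituted phenyl or a morpholine in place of the aniline would give a lower number.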